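Leaving the 4-methylpiperazine on the thiocarbonyl carbon

A few compounds are considered here, and "the series" means these few. Any claim that something is new, unique, unknown or untested is made for them only; others in the source may bear on it.

- compound 1 `CCCCCCCCCCCCCCCCOP(=O)(O)OCCSC(=S)N1CCCCCC1`: 32100 nM
- compound 2 `CCCCCCCCCCCCCCCCOP(=O)(O)OCCSC(=S)N1CCN(C)CC1`: 95200 nM

In a functional assay on PC-3 cells (Homo sapiens) for inhibition, read by MTT assay, with stated times of 18 h and 4 h (a lower number here means a stronger inhibitor, a higher number a weaker inhibitor), compound 2 holds the higher of the two numbers, at 95200 nM. Compound 3 `CCCCCCCCCCCCCCCCOP(=O)(O)OCCSC(=S)N1CCCCC1` carries piperidin-1-yl in place of 4-methylpiperazin-1-yl on a thiocarbonyl carbon. Among the compounds with values here, the only measured step bearing on this change is a 3.0-fold higher number from compound 1 to compound 2 (0.47 log units; beyond the scatter), which brought in 4-methylpiperazin-1-yl in place of azepan-1-yl. On the evidence of that step, removing 4-methylpiperazin-1-yl is expected to give a lower number by a similar amount. The estimated step is a 2.4-fold lower number from compound 2 to compound 3 (0.38 log units; beyond the scatter). Compound 3 is expected at 40000 nM, within an estimated range of 20000 nM to 80000 nM.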

Compound 3, half-maximal inhibitory concentration: 34300 nM
Beside the measured number, compound 3's estimate is 1.2-fold (0.07 log units) above it; the measured number falls inside the stated range.
By their numbers in this assay, from the lowest: compounds 1 and 3 (each within the scatter of the next); then compound 2.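

In this assay, piperidin-1-yl in place of 4-methylpiperazin-1-yl on the thiocarbonyl carbon gives a 2.8-fold lower number from compound 2 to compound 3 (0.44 log units; beyond the scatter), so this change is now measured directly. Piperidin-1-yl in place of azepan-1-yl gives a 1.1-fold higher number from compound 1 to compound 3 (0.03 log units; within the scatter), which leaves compound 1 and compound 3 indistinguishable here, with only the 4-methylpiperazin-1-yl of compound 2 standing apart. Nothing available here accounts for this difference. The compounds shown leave open whether the higher number goes with the second ring nitrogen or with its methyl. An unsubstituted piperazin-1-yl or a morpholin-4-yl at this position would bear on that.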